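The source may report more compounds than this note shows. Statements on the series, on what has been measured and on what is new or still open speak of the compounds shown alone.

Going by the values given here, compound 2 `O=C(CCCCCCc1ccccc1)c1ncc(-c2cncnc2)o1` gives 22 nM in an assay (Rattus norvegicus) for inhibition of Fatty-acid amide hydrolase 1 (Homo sapiens) (on this read-out higher numbers stand for weaker inhibition and lower numbers for stronger inhibition), the lower of the two numbers known so far. Among the compounds with values here, its only neighbour is compound 1 `COc1ccc(-c2cnc(C(=O)CCCCCCc3ccccc3)o2)cc1`, which gives 100 nM in this assay; that step, a 4.5-fold lower number from compound 1 to compound 2 (0.66 log units; beyond the scatter), is the single measured comparison and concerns only the exchange of one six-membered aromatic group for another on the shared core. Compound 3 `O=C(CCCCCCc1ccccc1)c1ncc(C(=O)N2CCSCC2)o1` is built from compound 2 by a different kind of change: (thiomorpholin-4-yl)carbonyl in place of pyrimidin-5-yl on an aromatic carbon. Within the data shown here, no measured step bears directly on replacing an aromatic ring by an amide-linked saturated ring at this position, so the one known step offers little guidance, and the expectation rests on compound 2 alone. The step from compound 2 to compound 3 is therefore expected to be small, a 2.3-fold higher number from compound 2 to compound 3 (0.36 log units; beyond the scatter), with wide uncertainty in either direction. Compound 3 is estimated at 50 nM in this assay, within a range from 8 nM to 400 nM.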

Compound 3, inhibition constant: 10 nM
Compound 3: the middle estimate sits 5.0-fold (0.70 log units) above what was measured, within the range that was stated.
By their numbers in this assay, from the lowest: compound 3; then compound 2; then compound 1.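

At this aromatic carbon next to the ring oxygen, the read-out in this assay does not depend on an aromatic ring: changing pyrimidin-5-yl to the non-aromatic (thiomorpholin-4-yl)carbonyl gives a 2.2-fold lower number from compound 2 to compound 3 (0.34 log units; beyond the scatter). The same group in place of 4-methoxyphenyl gives a 10-fold lower number from compound 1 to compound 3 (1.00 log units; beyond the scatter), the largest step among these compounds, so the position tolerates a saturated ring joined through a carbonyl as well as the aromatic groups. Nothing available accounts for either step.

The compounds shown leave open whether the ring sulfur matters, which a morpholine amide or a piperidine amide would address. They also leave open whether the carbonyl link matters, and how an ester, a carboxylic acid or an amide keeping its amide hydrogen would compare at this position.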